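Replacing a prenyl ether with a difluorophenyl carbamate

The source may hold more compounds than are shown below. What is called first, only, known or untested is meant among the compounds shown, and "the series" means these compounds.

Measured compounds:
- compound 1, `CC(C)=CCC/C(C)=C/CC1Cc2c(O)cc(=O)n(CCCO)c2CC1(C)C`: 28.7%
- compound 2, `CC(C)=CCOc1cc(=O)n(CCCO)c2c1CC(CC=C(C)C)C(C)(C)C2`: 20.7%

Both compounds were tested in a functional assay on PANC-1 cells (Homo sapiens) for inhibition, read by MTT assay, with a stated time of 24 h, tested at 10 uM; a higher number here means more inhibition at the concentration tested (going by the name of the read-out), a lower number less inhibition. Compound 1 gives 28.7% and compound 2 gives 20.7%. Compound 2 has the lowest of the two numbers, but the gap to compound 1 lies within the usual scatter of this kind of measurement, so the two cannot be ranked against each other on these data alone.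

The step under study leads from compound 2 to compound 3, `CC(C)=CCC1Cc2c(OC(=O)Nc3ccc(F)cc3F)cc(=O)n(CCCO)c2CC1(C)C`. The change is confined to one place on the shared core: (2,4-difluorophenyl)carbamoyl in place of 3-methylbut-2-en-1-yl on an oxygen on an aromatic ring. Compound 2 and compound 3 therefore share the same ring framework and the same hydroxypropyl chain; they differ only in what the oxygen on the aromatic ring carries.

Among the measured compounds shown here, no pair of measured compounds differing in a single place is available, so there is no reference step to calibrate how large a change in this assay such a swap might bring. The expectation must rest on the two numbers above and on the size of the structural change. Because compound 2 gives 20.7%, only modest inhibition, there is room for the number to move in either direction. The step from compound 2 to compound 3 is expected to be a small rise, a number 9.3 percentage points higher from compound 2 to compound 3 (within the scatter), of about the size of the scatter. Compound 3 is thus estimated at 30%, with a plausible range from 10% to 55%.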

Compound 3, a percentage reported as inhibition, at one concentration (the size of the read-out at that concentration, not a potency): 69.7%
Compound 3: middle estimate off by 39.7 percentage points, on the low side; the whole stated range lies below it.
By their numbers in this assay, from the lowest: compounds 2 and 1 (each within the scatter of the next); then compound 3.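

In this assay, among the compounds shown here, the group carried by the oxygen on an aromatic ring proves able to change the read-out strongly: putting (2,4-difluorophenyl)carbamoyl in place of 3-methylbut-2-en-1-yl gives a number 49 percentage points higher from compound 2 to compound 3 (beyond the scatter), the first step in this set that differs in one place and so the first direct view of this position. The change is not a single feature, however: a chain with no ring and no hydrogen-bond donors or acceptors leaves, and a larger group with a six-membered aromatic ring, two fluorines, a hydrogen-bond donor and a hydrogen-bond acceptor enters. No measurement here explains the rise or ties it to any one of these features.

Which part of the new group goes with the higher number stays open: a plain phenyl carbamoyl group without fluorine would test the role of the two fluorines, and an acetyl group on the same oxygen would test the role of the aromatic ring and the amide hydrogen. Potency also stays open, as this reading comes from a single concentration in one cell line, and a series of lower concentrations would be needed to settle it.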